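A few compounds are considered here, and "the series" means these few. Any claim that something is new, unique, unknown or untested is made for them only; others in the source may bear on it.

In a functional assay on cells (Cancer cell lines, Homo sapiens) for cytotoxicity, with a stated time of 48 h (a higher number here means a weaker inhibitor of growth, a lower number a stronger inhibitor of growth), compound 1 `COc1cc2c(/C=C3/C(=O)Nc4ccc(O)cc43)c(Cl)n(Cc3cc(OC)c(OC)c(OC)c3)c2cc1C` gives 1410 nM. Compound 2 `COc1c(/C=C2/C(=O)Nc3ccccc32)c2ccccc2n1-c1ccccc1` gives 1230 nM in this assay. Of the two numbers compound 1 carries the higher one, but the gap to compound 2 lies within the scatter, so no order between them is claimed. Compound 3 `COc1ccc2c(c1)/C(=C\c1c(Cl)n(Cc3cc(OC)c(OC)c(OC)c3)c3cc(C)c(OC)cc13)C(=O)N2` differs from compound 1 by methyl in place of hydrogen on an oxygen on an aromatic ring. For the measured compounds named here, no measured pair shows this change, so its size can only be estimated from compound 1 alone. The step is expected to be a 1.1-fold higher number from compound 1 to compound 3 (0.03 log units; within the scatter), with no move beyond the scatter expected in either direction. Compound 3 is estimated at 1500 nM, with a range from 600 nM to 4000 nM.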

Compound 3, concentration for 50% growth inhibition: 10200 nM
Estimate against measurement, compound 3: 6.8-fold (0.83 log units) below, and the stated range ends below it.
By their numbers in this assay, from the lowest: compounds 2 and 1 (each within the scatter of the next); then compound 3.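

In this assay hydroxy to methoxy on this oxygen on an aromatic ring gives a 7.2-fold higher number from compound 1 to compound 3 (0.86 log units; beyond the scatter) and so is no silent change: this position responds to a single added methyl. Within this pair, the free hydroxy of compound 1 goes with the lower number. Nothing at hand explains the step.

Still open, from the compounds shown here alone, is how an amine or a longer chain such as ethoxy would read at this place. A single pair also leaves open whether the step would hold on a core other than that of compound 1.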